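The source may report more compounds than this note shows. Statements on the series, on what has been measured and on what is new or still open speak of the compounds shown alone.

Series notes. Compound 1 `COc1ccc2c(O[C@H]3C[C@H]4C(=O)N(C)CCCC/C=C/[C@@H]5C[C@@]5(C(=O)NS(=O)(=O)C5(C)CC5)NC(=O)N4C3)cc(-c3nc(C4CCC4)cs3)nc2c1Cl`, compound 2 `COc1ccc2c(O[C@H]3C[C@H]4C(=O)N(C)CCCC/C=C/[C@@H]5C[C@@]5(C(=O)NS(=O)(=O)C5(C)CC5)NC(=O)N4C3)cc(-c3cc(C(C)C)on3)nc2c1Cl` and compound 3 `COc1ccc2c(O[C@H]3C[C@H]4C(=O)N(C)CCCC/C=C/[C@@H]5C[C@@]5(C(=O)NS(=O)(=O)C5(C)CC5)NC(=O)N4C3)cc(-n3cc(C(F)(F)F)cn3)nc2c1Cl` share one macrocyclic core and differ only in the azole on the quinoline carbon. In an ADME assay on Huh-7 cells (Homo sapiens) for cytotoxicity, read by colorimetric assay (a lower number here means that less compound is tolerated, a higher number that more compound is tolerated), compound 1 gives 75000 nM, compound 2 gives 75000 nM and compound 3 gives 21900 nM, the lowest number of the three; the steps of a 3.4-fold lower number from compound 1 to compound 3 (0.53 log units; beyond the scatter) and a 3.4-fold lower number from compound 2 to compound 3 (0.53 log units; beyond the scatter) are both modest but beyond the scatter, while no change at the digits printed from compound 1 to compound 2 (within the scatter). Compound 4 `COc1ccc2c(O[C@H]3C[C@H]4C(=O)N(C)CCCC/C=C/[C@@H]5C[C@@]5(C(=O)NS(=O)(=O)C5(C)CC5)NC(=O)N4C3)cc(-n3cc(C(C)C)nn3)nc2c1Cl` follows from compound 3 by 4-isopropyl-1H-1,2,3-triazol-1-yl in place of 4-(trifluoromethyl)-1H-pyrazol-1-yl on an aromatic carbon. The two steps into compound 3 both bear on this change, since each swaps the same azole for another, and both ran the same modest size; a step of similar size back upward in this assay is therefore expected, a 1.8-fold higher number from compound 3 to compound 4 (0.26 log units; within the scatter). For compound 4 the estimate is 40000 nM, range 15000 nM to 100000 nM.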

Compound 4, half-maximal cytotoxic concentration: 28500 nM
Compound 4: middle estimate off by 1.4-fold (0.15 log units), on the high side; the range from low to high includes it.
By their numbers in this assay, from the lowest: compounds 3 and 4 (each within the scatter of the next); then compounds 1 and 2 (each within the scatter of the next).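

In this assay, the 4-isopropyl-1H-1,2,3-triazol-1-yl group does not separate from the 4-(trifluoromethyl)-1H-pyrazol-1-yl group (a 1.3-fold higher number from compound 3 to compound 4 (0.11 log units; within the scatter)), so the lower level at this position does not need a trifluoromethyl group. Isopropyl alone does not restore the level, as the ring carrying it differs in one step (a 2.6-fold lower number from compound 2 to compound 4 (0.42 log units; beyond the scatter)), and the thiazole comparison runs the same way (a 2.6-fold lower number from compound 1 to compound 4 (0.42 log units; beyond the scatter)). No measured evidence accounts for this split. Open, on these data alone, is whether a trifluoromethyl-bearing oxazole would follow its ring or its substituent. Also open, as far as these compounds go, is how an amine or carboxylic acid on these rings would read.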